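A Nitro Group in Place of Bromo

This account rests on a few compounds, and the source may have more. Where it says the series, first, only, none or still open, it means among the compounds named here.

In a functional assay on MCF7 cells (Homo sapiens) for inhibition, read by sulforhodamine B assay, with a stated time of 48 h (on this read-out higher numbers stand for weaker inhibition of growth and lower numbers for stronger inhibition of growth), compound 1 (`N#CCC(=O)N/N=C(/CBr)c1ccc(Br)cc1`) gives 40600 nM. Compound 2 (`N#CCC1=NN=C(c2ccc(Br)cc2)C(CC(=O)c2ccc(Br)cc2)O1`) gives 30400 nM, which lies within the usual scatter of compound 1, so these numbers do not separate the two. Compound 3 (`N#CCC1=NN=C(c2ccc(Br)cc2)C(CC(=O)c2ccc([N+](=O)[O-])cc2)O1`) has not yet been measured. It differs from compound 2 in one place: nitro in place of bromo on an aromatic carbon. In words, this is nitro in place of bromo on an aromatic carbon, turning 4-bromophenyl into 4-nitrophenyl. Among the compounds with values here, no measured pair shows what this change does, so the expectation rests only on compound 2 at 30400 nM. No step beyond the scatter is expected in this assay, in either direction. The expected change is a 1.2-fold lower number from compound 2 to compound 3 (0.08 log units; within the scatter). The estimate for compound 3 is 25000 nM, with an expected range of 9000 nM to 60000 nM.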

Compound 3, concentration for 50% growth inhibition: 32000 nM
Estimate against measurement, compound 3: 1.3-fold (0.11 log units) below; low and high end bracket the measured number.
By their numbers in this assay, from the lowest: compounds 2, 3 and 1 (each within the scatter of the next).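

Within the data shown here, the step of a 1.1-fold higher number from compound 2 to compound 3 (0.02 log units; within the scatter) in this assay is the first measured comparison at this position, where the two earlier compounds could show nothing about a single change. On this read-out, 4-bromophenyl and 4-nitrophenyl are not separated, even though nitro is the larger group and carries hydrogen-bond acceptors that bromo lacks. No measurement at hand explains why the two groups read alike.

On these data alone, whether an amine, a carboxylic acid or a longer chain at this same aromatic carbon would move the number beyond the scatter remains open. Also open, as far as these compounds go, is what a change at the other 4-bromophenyl group, shared by compound 2 and compound 3, would do, since these two compounds differ only at the one place.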